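Swapping the Aryl Group on the Acrylamide Chain

The source may report more compounds than this note shows. Statements on the series, on what has been measured and on what is new or still open speak of the compounds shown alone.

Within the data shown here, in a functional assay on HepG2 cells (Homo sapiens) for antiproliferative activity, read by MTT assay, with a stated time of 48 h (on this read-out lower numbers stand for stronger inhibition and higher numbers for weaker inhibition), compound 3 `O=C(/C=C/c1ncc2ccccc2n1)Nc1ccc2ncnc(Nc3cccc(Cl)c3)c2c1` gives 7790 nM, the second highest of the three numbers measured so far. Its nearest neighbour is compound 2 `O=C(/C=C/c1cccnc1)Nc1ccc2ncnc(Nc3cccc(Cl)c3)c2c1`, which in this assay gives 9120 nM. The furthest is compound 1 `Cc1cccc(CNc2ccc3ncnc(Nc4cccc(Cl)c4)c3c2)n1`, which in this assay gives 3630 nM, a gap from compound 3 that lies beyond the scatter. Compound 4 `O=C(/C=C/c1ccc(Br)s1)Nc1ccc2ncnc(Nc3cccc(Cl)c3)c2c1` has not yet been measured. It differs from compound 3 in one place: 5-bromothiophen-2-yl in place of quinazolin-2-yl on a double-bonded chain carbon bound to a double-bonded chain carbon. Among the measured compounds shown here, the only measured step that bears on this change is the earlier exchange of the aryl group at the same chain position, a 1.2-fold lower number from compound 2 to compound 3 (0.07 log units; within the scatter). That step stayed within the scatter, so exchanging the aryl group on this double-bonded chain carbon has so far moved the number very little. For the measured compounds named here, no measured step involves a bromothiophene, so the expectation rests on that single comparison. Compound 4 is therefore expected to show a step of a 1.1-fold lower number from compound 3 to compound 4 (0.05 log units; within the scatter), which should not go beyond the scatter. The estimate for compound 4 in this assay is 7000 nM, with a range from 3000 nM to 16000 nM.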

Compound 4, half-maximal inhibitory concentration: 8850 nM
The estimate for compound 4 lay 1.3-fold (0.10 log units) below the measured number; the measured number falls inside the stated range.
By their numbers in this assay, from the lowest: compound 1; then compounds 3, 4 and 2 (each within the scatter of the next).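

In this assay, the change from the two-ring quinazolin-2-yl to the smaller, single-ring 5-bromothiophen-2-yl on this double-bonded chain carbon gives a 1.1-fold higher number from compound 3 to compound 4 (0.06 log units; within the scatter). The exchange of pyridin-3-yl for the same group gives a 1.0-fold lower number from compound 2 to compound 4 (0.01 log units; within the scatter), so a five-membered aromatic ring carrying sulfur and bromine now joins the two nitrogen-containing aryl groups, and none of the three steps among these compounds leaves the scatter. Across compounds 2, 3 and 4, then, neither the size of the aryl group nor its ring type goes with any readable change in the number, although nothing measured here explains this insensitivity.

All three groups at this place are aromatic rings, so the compounds shown leave open whether an amine such as dimethylamino or a carboxylic acid on this double-bonded chain carbon would take the number beyond the scatter. They also leave open whether a thiophen-2-yl group without the bromine would stay within the scatter of compound 4.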